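Thiophene versus benzofuran nucleosides in HeLa antiproliferation

A few compounds are considered here, and "the series" means these few. Any claim that something is new, unique, unknown or untested is made for them only; others in the source may bear on it.

Measured compounds:
- compound 1 `O=c1[nH]cnc2c1c(-c1ccsc1)cn2[C@@H]1O[C@H](CO)[C@@H](O)[C@H]1O`: in a functional assay on HeLa S3 cells (Homo sapiens) for antiproliferative activity, read by XTT assay, with a stated time of 72 h (on this read-out higher numbers stand for weaker inhibition and lower numbers for stronger inhibition), compound 1 gives > 20000 nM, a limit of the assay rather than a number
- compound 2 `O=c1[nH]cnc2c1c(-c1cc3ccccc3o1)cn2[C@@H]1O[C@H](CO)[C@@H](O)[C@H]1O`: compound 2 gives > 20000 nM, again a limit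
- compound 3 `Cc1nc(N)c2c(-c3cc4ccccc4o3)cn([C@@H]3O[C@H](CO)[C@@H](O)[C@H]3O)c2n1`: compound 3 gives > 20000 nM, also a limit

All three values sit at the limit of > 20000 nM in this assay, at which 3 of the 3 values shown sit, so no ordering among them can be read. From compound 2 to compound 1 the change is thiophen-3-yl in place of 1-benzofuran-2-yl on an aromatic carbon, and the step that the two limits leave unreadable from compound 2 to compound 1 cannot be sized because the limit of > 20000 nM in this assay, at which 3 of the 3 values shown sit, caps both ends. The difference between the cores of compound 2 and compound 3 is not broken down here. Compound 4 `Cc1nc(N)c2c(-c3ccsc3)cn([C@@H]3O[C@H](CO)[C@@H](O)[C@H]3O)c2n1` carries the same change on the core of compound 3, namely (thiophen-3-yl in place of 1-benzofuran-2-yl on an aromatic carbon). Because the limit of > 20000 nM in this assay, at which 3 of the 3 values shown sit, holds for compound 3 and the same change left compound 1 at the limit, compound 4 is expected to stay at the limit, the step that the limit leaves unreadable from compound 3 to compound 4 being expected to be unreadable. Compound 4 is estimated at 40000 nM with a range from 15000 nM to 150000 nM.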

Compound 4, half-maximal inhibitory concentration: > 20000 nM
Compound 4 gave a limit, no number (the forecaster's own chance of this, stated with the estimate: 85%); the middle value lies beyond the limit too.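

No new step can be read between compound 3 and compound 4, nor between any other pair among compounds 1 to 4: the limit of > 20000 nM in this assay, at which 4 of the 4 values shown sit. From the compounds shown here alone, whether thiophen-3-yl and 1-benzofuran-2-yl differ in effect on either core remains open.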